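Dichlorophenyl sulfonamide diamides: methyl for chloro on the ring

The source may hold more compounds than are shown below. What is called first, only, known or untested is meant among the compounds shown, and "the series" means these compounds.

Measured compounds:
compound 1, `CCNC(=O)CCC(NS(=O)(=O)c1cc(Cl)ccc1Cl)C(=O)NCC`, 12.9%
compound 2, `CCCCNC(=O)CCC(NS(=O)(=O)c1cc(Cl)ccc1Cl)C(=O)NCCCC`, 15.8%
compound 3, `CCNC(=O)CCC(NS(=O)(=O)c1cc(C)ccc1Cl)C(=O)NCC`, 31.8%

The series is read in a functional assay on IMR-32 cells (Homo sapiens) for cytotoxicity, read by MTT assay, tested at 60 ug/mL; on this read-out lower numbers stand for less inhibition and higher numbers for more inhibition at the one concentration tested (going by the name of the read-out). Compound 1 gives 12.9%. The core of compound 2 differs from that of compound 1 in a way that is not broken down here. Compound 2 gives 15.8%; the two numbers lie within the scatter of each other, so nothing is said about their order. Compound 3 gives 31.8%.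

Between compound 1 and compound 3 one change is made: methyl in place of chloro on an aromatic carbon. The step it produced is a number 18.9 percentage points higher from compound 1 to compound 3 (beyond the scatter).

Compound 4, `CCCCNC(=O)CCC(NS(=O)(=O)c1cc(C)ccc1Cl)C(=O)NCCCC`, is not yet measured in this assay. It stands to compound 2 as compound 3 stands to compound 1: methyl in place of chloro on an aromatic carbon. The place of the change reads the same in both pairs, so it is the same change, made here on the core of compound 2 rather than that of compound 1.

The expectation for compound 4 rests on one precedent only. Because a number 18.9 percentage points higher from compound 1 to compound 3 (beyond the scatter) lies beyond the scatter, a step of comparable size is expected from compound 2, estimated as a number 18.2 percentage points higher from compound 2 to compound 4 (beyond the scatter). With a single prior example and cores that are not broken down against each other, the range kept is wide. Compound 4 is expected to give 34%, between 20% and 48%.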

Compound 4, a percentage reported as inhibition, at one concentration (the size of the read-out at that concentration, not a potency): 18%
Beside the measured number, compound 4's estimate is 16 percentage points above it; measured number outside the range, below it.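

In this assay, methyl in place of chloro, the change from 2,5-dichlorophenyl to 2-chloro-5-methylphenyl, does not carry over at a constant size from one core to the other: the same change on two cores in this assay, a number 18.9 percentage points higher (beyond the scatter) from compound 1 to compound 3 and a number 2.2 percentage points higher (within the scatter) from compound 2 to compound 4, 16.7 percentage points apart, beyond the scatter of two such steps

On the core of compound 2, the new step, a number 2.2 percentage points higher from compound 2 to compound 4 (within the scatter), stays inside the scatter, so the rise seen on the core of compound 1 cannot be transferred to another core in this series as a fixed increment. What these two pairs do not show is the source of the difference, or whether either step is typical: they give one step per core, and nothing here separates a real dependence on the core from an effect confined to one of these two pairs.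

The compounds shown leave open how the size of this step varies with the amide chains, with only the ethyl and butyl amides to go on, so a propyl chain or a longer chain would be needed to tell a trend from a two-point contrast. Also open, going by these compounds, is whether a different group on the same aromatic carbon, such as methoxy or nitrile, would follow methyl on either core.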